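A few compounds are considered here, and "the series" means these few. Any claim that something is new, unique, unknown or untested is made for them only; others in the source may bear on it.

Of the compounds shown here, three with a shared core have been tested in a functional assay on the whole organism (Tail, strain ICR) with Mus musculus as the target, in the tail flick test, with a stated time of 90 min, at a dose of 25 umol/kg by the oral route; on this read-out lower numbers stand for a weaker effect and higher numbers for a stronger effect at the one dose given. Compound 1, `N=C(N)NCCC[C@H](NC(=O)CN(c1nc(Cl)nc2[nH]cnc12)C1CC1)C(=O)OCc1ccccc1`, gives 30.4% in this assay. Compound 2, `C[C@@H](O)[C@H](NC(=O)CN(c1nc(Cl)nc2[nH]cnc12)C1CC1)C(=O)O`, gives 35.9% in this assay. Compound 3, `CC(C)[C@H](NC(=O)CN(c1ncnc2c1ncn2C1CCCCO1)C1CC1)C(=O)OCc1ccccc1`, gives 30.1% in this assay. The three numbers sit close together: the gaps from compound 2 to compound 1 and to compound 3 both fall within the usual scatter of repeated measurements, so on these numbers compound 2 cannot be told apart from either of the other two.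

The next compound, compound 4, `O=C(O)C[C@H](NC(=O)CN(c1nc(Cl)nc2[nH]cnc12)C1CC1)C(=O)O`, has not yet been measured. It differs from compound 2 in a single place: carboxymethyl in place of 1-hydroxyethyl on a saturated chain carbon bound to an amide-type nitrogen and a carbonyl carbon. Within the data shown here, no pair of measured compounds shows what such a change does in this assay, so there is no measured step to lean on. With the three measured compounds lying so close together and nothing showing a change of this kind, the expectation is that compound 4 will give a number near that of compound 2, with a step from compound 2 to compound 4 of a number 2.9 percentage points lower from compound 2 to compound 4 (within the scatter), which means no change beyond the scatter in either direction. For compound 4 the estimated value in this assay is 33%, expected to fall between 18% and 48%.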

Compound 4, a percentage reported as activity, at one dose (the size of the read-out at that dose, not a potency): 25.1%
For compound 4 the middle estimate is 7.9 percentage points above the measured one, within the range that was stated.
By their numbers in this assay, from the lowest: compounds 4, 3, 1 and 2 (each within the scatter of the next, the first and the last beyond it).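

Carboxymethyl in place of 1-hydroxyethyl on a saturated chain carbon bound to an amide-type nitrogen and a carbonyl carbon gives a number 10.8 percentage points lower from compound 2 to compound 4 (beyond the scatter) in this assay and is the first step measured at this position. It shows that the group at this place can shift the read-out by a modest amount beyond the scatter, and that this change goes towards a weaker effect at the one dose given. The hydrogen-bond donor and acceptor counts and the lack of net charge are the same for the two groups, so those counts do not separate them, and nothing measured here accounts for the step.

The compounds shown leave open what other groups do at this place, such as an amine or a longer chain ending in a carboxylic acid, and whether either would read closer to compound 2 or to compound 4. This single step gives a size and direction for one pair only, so it cannot yet be read as a trend for this position.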